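Carbamate series: chloro-to-methoxy swap on the benzylic carbon

The source may report more compounds than this note shows. Statements on the series, on what has been measured and on what is new or still open speak of the compounds shown alone.

Measured compounds in a functional assay on the whole organism for inhibition, with Mus musculus as the target, in the writhing test, with a stated time of 1 h, at a dose of 10 mg/kg by the oral route; on this read-out higher numbers stand for more inhibition at the one dose given (going by the name of the read-out) and lower numbers for less inhibition:
compound 1 `COc1ccc(N2CCN(CCC(OC(N)=O)c3ccc(Cl)cc3)CC2)cc1` gives 51%
compound 2 `COc1ccc(N2CCN(CCC(OC(N)=O)c3ccccc3)CC2)c(OC)c1` gives 19%
compound 3 `COc1ccc(N2CCN(CCC(OC(N)=O)c3ccc(Cl)c(Cl)c3)CC2)cc1` gives 61%

Compound 3 stands highest of the three numbers in this assay, though its nearest neighbour is compound 1, and the step of a number 10 percentage points higher from compound 1 to compound 3 (within the scatter) lies within the scatter, so the two cannot be ordered. Compound 2, which also carries a different core, sits well below both, a gap beyond the scatter.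

Compound 4 `COc1ccc(C(CCN2CCN(c3ccc(OC)cc3)CC2)OC(N)=O)cc1` is not yet measured. It differs from compound 3 in one place: 4-methoxyphenyl in place of 3,4-dichlorophenyl on a saturated chain carbon bound to an oxygen next to a carbonyl group and a saturated chain carbon.

Among the measured compounds shown here, only one measured step bears on the aryl group at this position, and it shows that adding chloro to hydrogen on the aromatic ring changed the read-out by no more than the scatter, from compound 1 to compound 3. For the measured compounds named here, no measured step covers methoxy at this ring with the shared core; compound 2 carries an unsubstituted ring but a different core, so its low value cannot be assigned to the ring alone. The expected step of a number 21 percentage points lower from compound 3 to compound 4 (beyond the scatter) is therefore downward but uncertain. Compound 4 is estimated at 40%, within the range 15% to 65%.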

Compound 4, a percentage reported as inhibition, in the whole organism at one dose (the size of the read-out at that dose, not a potency): 53%
Compound 4: middle estimate off by 13 percentage points, on the low side, within the range that was stated.
By their numbers in this assay, from the lowest: compound 2; then compounds 1, 4 and 3 (each within the scatter of the next).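

In this assay, 4-methoxyphenyl in place of 3,4-dichlorophenyl on this saturated chain carbon gives a number 8 percentage points lower from compound 3 to compound 4 (within the scatter). Methoxy in place of chloro on the aromatic carbon gives a number 2 percentage points higher from compound 1 to compound 4 (within the scatter), so this is the first reading of methoxy on the shared core, and the read-out does not separate it from the chloro-bearing rings: among compounds 1, 3 and 4, chloro is not required for the read-out at this dose. No measurement on hand accounts for this result.

On these data alone, an unsubstituted ring on the shared core remains open, since compound 2 also differs in its core and so cannot stand in for it. Also open, as far as these compounds go, is whether an amine or a carboxylic acid on this ring would hold the read-out at the level of these three compounds.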